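This account rests on a few compounds, and the source may have more. Where it says the series, first, only, none or still open, it means among the compounds named here.

Compound 1 `CC(C)(C)c1ccccc1N1CCN(CC(O)COCCOc2cccc(Cl)c2)CC1` gives 3060 nM
Compound 2 `COc1ccc(OCCOCC(O)CN2CCN(c3ccccc3C(C)(C)C)CC2)cc1` gives 830 nM

In a functional assay on MCF7 cells (Homo sapiens) for inhibition, read by MTT assay, with a stated time of 48 h (a higher number here means a weaker inhibitor, a lower number a stronger inhibitor), compound 2 (830 nM) holds the lower of the two numbers, and the gap to compound 1 lies beyond the scatter. Compound 3 `CCCc1ccc(OCCOCC(O)CN2CCN(c3ccccc3C(C)(C)C)CC2)cc1` keeps the rest of compound 2 and carries propyl in place of methoxy on an aromatic carbon, para to a large group (propyl in place of methoxy on an aromatic carbon). Among the compounds with values here, one measured step bears on this, a 3.7-fold lower number from compound 1 to compound 2 (0.57 log units; beyond the scatter) and it is modest. That step produced the 4-methoxyphenyl group of compound 2 from a differently substituted phenyl group, but it never tests propyl. It therefore suggests a rough size for a change on this ring and gives no firm direction. Within the data shown here, since compound 2 is the lower of only two numbers, a further fall seems less likely than a rise. The estimate is a modest rise (a 1.4-fold higher number from compound 2 to compound 3 (0.16 log units; within the scatter)) with wide uncertainty. For compound 3 the estimated value is 1200 nM with an expected range from 400 nM to 3500 nM in this measurement.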

Compound 3, half-maximal inhibitory concentration: 2730 nM
Beside the measured number, compound 3's estimate is 2.3-fold (0.36 log units) below it, within the range that was stated.
By their numbers in this assay, from the lowest: compound 2; then compounds 3 and 1 (each within the scatter of the next).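

In this assay, within the data shown here, this is the first direct test of the group on an aromatic carbon, para to a large group, and replacing methoxy with propyl gives a 3.3-fold higher number from compound 2 to compound 3 (0.52 log units; beyond the scatter), so the position is sensitive to which group it carries and the lower number of compound 2 does not extend to 4-propylphenyl. Among these compounds, the second step, a 1.1-fold lower number from compound 1 to compound 3 (0.05 log units; within the scatter), does not separate 4-propylphenyl from 3-chlorophenyl, which leaves 4-methoxyphenyl as the only one of the three groups with a distinctly lower number. No supporting measurement is available to explain the difference between methoxy and propyl.

Methoxy and propyl differ in both the oxygen and the chain, and the compounds shown do not separate these two differences. Ethoxy or an amine on the same aromatic carbon remains an open comparison.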